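The source may report more compounds than this note shows. Statements on the series, on what has been measured and on what is new or still open speak of the compounds shown alone.

Compound 1, `CC[C@H](C)[C@H](NC(=O)c1cccc(Cn2ccnc2)c1)C(=O)NNS(=O)(=O)c1ccccc1`, gives 6% in an assay on HEK293 cells for displacement of a labelled ligand from Type-2 angiotensin II receptor (Homo sapiens), tested at 1 uM; a higher number here means a stronger effect of the compound at the concentration tested, a lower number a weaker effect.
Compound 2, `CC[C@H](C)[C@H](NC(=O)c1cccc(Cn2ccnc2)c1)C(=O)NNS(=O)(=O)c1ccc(C)cc1`, gives 4% in this assay.
Compound 3, `CC[C@H](C)[C@H](NC(=O)c1cccc(Cn2ccnc2)c1)C(=O)NNS(=O)(=O)c1ccc(OC)cc1`, gives 3% in this assay.

Compound 3 has the lowest of the three numbers in this assay, but its values sit within the scatter of compound 2 and of compound 1, so the three compounds cannot be told apart on these numbers. Compound 4, `CC[C@H](C)[C@H](NC(=O)c1cccc(Cn2ccnc2)c1)C(=O)NNS(=O)(=O)c1c(C)cc(C)cc1C`, has not yet been measured. It differs from compound 3 in one place: 2,4,6-trimethylphenyl in place of 4-methoxyphenyl on a sulfonyl sulfur. Among the measured compounds shown here, no measured step makes this exact exchange. For the measured compounds named here, the steps that bear on it all change the same aromatic ring: a number 2 percentage points lower from compound 1 to compound 2 (within the scatter), a number 3 percentage points lower from compound 1 to compound 3 (within the scatter) and a number 1 percentage points lower from compound 2 to compound 3 (within the scatter), each within the scatter. Three different groups on this ring have therefore left the number essentially unchanged, which gives no ground to expect a step beyond the scatter in this assay for compound 4. The expected step is a number 2 percentage points higher from compound 3 to compound 4 (within the scatter). Compound 4 is estimated to give 5% in this assay, in a range from -5% to 15%.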

Compound 4, a percentage reported as inhibition, at one concentration (the size of the read-out at that concentration, not a potency): 10%
Compound 4: the middle estimate sits 5 percentage points below what was measured; the measured number falls inside the stated range.
By their numbers in this assay, from the lowest: compounds 3, 2, 1 and 4 (each within the scatter of the next).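

Replacing the ring on the sulfonyl sulfur with 2,4,6-trimethylphenyl, which carries three methyl groups and no oxygen, still does not move the result in this assay beyond the scatter: the steps are a number 7 percentage points higher from compound 3 to compound 4 (within the scatter), a number 6 percentage points higher from compound 2 to compound 4 (within the scatter) and a number 4 percentage points higher from compound 1 to compound 4 (within the scatter). The four aromatic groups at this place therefore cannot be told apart, and adding more methyl groups to the ring has not produced a clear change. No measurement here offers an explanation for these small differences.

As far as these compounds go, it remains open whether a group of another kind on the sulfonyl sulfur, such as a plain alkyl chain or a phenyl ring bearing an amine or a carboxylic acid, would shift the number beyond the scatter. Changes to the shared core also remain open, and each compound has a reading at only one concentration, which shows the size of its effect at that concentration and nothing about other concentrations.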